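Carboxy for hydroxymethyl on the aromatic-nitrogen chain: compound 4

The source may hold more compounds than are shown below. What is called first, only, known or untested is meant among the compounds shown, and "the series" means these compounds.

Compound 1 `Cn1c(Cc2nn(C)c(=O)c3ccccc23)nnc1SCCCCCCCC(=O)Nc1ccc(Cl)cc1Cl` in an assay on NK92 cells for inhibition of interleukin-15 (Homo sapiens), read by AlphaScreen, with stated times of 30 min and 1 h (a lower number here means a stronger inhibitor, a higher number a weaker inhibitor), gives 190 nM. Compound 2 `CN(C)CCCn1nc(Cc2nnc(SCCCCCCCC(=O)Nc3ccc(Cl)cc3Cl)n2C)c2ccccc2c1=O` in this assay returns only the limit > 30000 nM. Compound 3 `Cn1c(Cc2nn(CCCO)c(=O)c3ccccc23)nnc1SCCCCCCCC(=O)Nc1ccc(Cl)cc1Cl` in this assay also returns only the limit > 30000 nM. Compound 3 therefore stands at the limit, where two of the three values sit (the limit of > 30000 nM in this assay, at which 2 of the 3 values shown sit); the steps of an at least 150-fold higher number from compound 1 to compound 2 (2.19 log units; beyond the scatter) and an at least 150-fold higher number from compound 1 to compound 3 (2.19 log units; beyond the scatter) are both large, while a step that the two limits leave unreadable from compound 2 to compound 3 cannot be read. Compound 4 `Cn1c(Cc2nn(CCC(=O)O)c(=O)c3ccccc23)nnc1SCCCCCCCC(=O)Nc1ccc(Cl)cc1Cl` differs from compound 3 by carboxy in place of hydroxymethyl on a saturated chain carbon, two bonds along the chain from an aromatic nitrogen. The substituted chain that carries both measured losses is kept in compound 4, so no return toward compound 1 is expected. Compound 4 is expected at 30000 nM, range 5000 nM to 100000 nM. The expected step is a number no higher from compound 3 to compound 4 (the limit leaves the size open), most likely again only a limit.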

Compound 4, half-maximal inhibitory concentration: > 30000 nM
Compound 4 ended at the assay's limit; the forecaster's own chance of this, stated with the estimate: 70%; the middle value lies on the limit itself.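

In this assay the carboxy-bearing chain also shows an at least 150-fold higher number from compound 1 to compound 4 (2.19 log units; beyond the scatter), so the loss at this position now covers chains carrying dimethylamino, hydroxy and carboxy. Compound 4 gives > 30000 nM, which is a limit and not a number. The steps among compound 2, compound 3 and compound 4 cannot be read, so these groups cannot be ranked, and most of the series shown sits at one limit: the limit of > 30000 nM in this assay, at which 3 of the 4 values shown sit.

On these data alone, whether the loss follows the chain itself or the groups it carries stays open. A plain propyl chain on the same aromatic nitrogen would separate the two.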